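A Thiophene Replaces Chlorophenyl on a Weak Cyclopropane Amide

A few compounds are considered here, and "the series" means these few. Any claim that something is new, unique, unknown or untested is made for them only; others in the source may bear on it.

Of the compounds shown here, two have been measured in a functional assay for agonist activity at G protein-coupled receptor 88 (Homo sapiens), read by HTRF and cAMP accumulation; a lower number here means that less compound is needed, a higher number that more compound is needed for the effect. Compound 1 `NC1(CN(C(=O)[C@@H]2C[C@H]2c2ccccc2)c2ccc(-c3ccccc3)cc2)CCCC1` gives 0.57 nM. Compound 2 `CC[C@H](C)[C@H](N)CN(C(=O)[C@@H]1C[C@H]1c1ccc(Cl)cc1)c1ccc(-c2ccccc2)cc1` gives 4300 nM, the higher of the two values, so compound 2 needs far more material than compound 1 for the same effect. Compound 3 `CC[C@H](C)[C@H](N)CN(C(=O)[C@@H]1C[C@H]1c1ccsc1)c1ccc(-c2ccccc2)cc1` differs from compound 2 in one place: thiophen-3-yl in place of 4-chlorophenyl on a saturated ring carbon. For the measured compounds named here, no measured pair shows this change, so the expectation rests on compound 2 alone. The step of a 1.4-fold higher number from compound 2 to compound 3 (0.14 log units; within the scatter) is expected to be small, within the usual scatter or a modest rise. Compound 3 is therefore estimated at 6000 nM, between 1500 nM and 25000 nM.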

Compound 3, half-maximal effective concentration: 450 nM
Compound 3: middle estimate off by 13-fold (1.12 log units), on the high side; measured number below the stated range.
By their numbers in this assay, from the lowest: compound 1; then compound 3; then compound 2.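

In this assay, the group on this saturated ring carbon of the three-membered ring clearly affects the result: thiophen-3-yl in place of 4-chlorophenyl gives a 9.6-fold lower number from compound 2 to compound 3 (0.98 log units; beyond the scatter). So a five-membered aromatic ring with a sulfur atom is accepted here, and less compound is needed than with the 4-chlorophenyl ring. Nothing measured here accounts for this gain.

Whether the gain is specific to thiophen-3-yl remains open, as thiophen-2-yl and furan-3-yl at this position are not among the compounds shown. Also unknown is whether the same change would have a similar effect on the core of compound 1.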